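Pyrrol-2-yl ketone in a quinoline-enone series

The source may hold more compounds than are shown below. What is called first, only, known or untested is meant among the compounds shown, and "the series" means these compounds.

Measured compounds:
compound 1, `COc1ccc(-c2cc3ccccc3nc2/C=C/C(=O)c2ccc(OC)c(OC)c2)cc1`: 3260 nM
compound 2, `COc1ccc(-c2cc3ccccc3nc2/C=C/C(=O)c2ccccn2)cc1`: 370 nM
compound 3, `COc1ccc(-c2cc3ccccc3nc2/C=C/C(=O)c2ccc(Br)s2)cc1`: 520 nM

In a functional assay on SK-BR-3 cells (Homo sapiens) for antiproliferative activity, read by XTT assay, with a stated time of 72 h (on this read-out higher numbers stand for weaker inhibition and lower numbers for stronger inhibition), compound 3 stands second highest of the three numbers. Its nearest neighbour is compound 2: a 1.4-fold higher number from compound 2 to compound 3 (0.15 log units; within the scatter), so the two cannot be told apart. Its furthest is compound 1: a 6.3-fold lower number from compound 1 to compound 3 (0.80 log units; beyond the scatter). The companion step from the same starting point, an 8.8-fold lower number from compound 1 to compound 2 (0.95 log units; beyond the scatter), is of similar size, so replacing the 3,4-dimethoxyphenyl of compound 1 by either small heteroaryl gave a modest gain.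

Compound 4, `COc1ccc(-c2cc3ccccc3nc2/C=C/C(=O)c2ccc[nH]2)cc1`, differs from compound 3 as follows: 1H-pyrrol-2-yl in place of 5-bromothiophen-2-yl on a carbonyl carbon. Going by the values given here, no measured step replaces a five-membered heteroaryl by another five-membered heteroaryl on this carbonyl carbon, so the bearing steps are indirect. Among the compounds with values here, the only direct comparison among small heteroaryls is compound 2 against compound 3, which lies within the scatter. On that basis compound 4 is expected to stay close to compound 3, with no step beyond the scatter in either direction, i.e. a 1.0-fold lower number from compound 3 to compound 4 (0.02 log units; within the scatter).

Compound 4 is therefore estimated at 500 nM in this assay, with a range from 200 nM to 1500 nM.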

Compound 4, half-maximal inhibitory concentration: > 10000 nM
Compound 4: only a limit was reported; the forecaster's own chance of this, stated with the estimate: 5%; middle value at least 20-fold (1.30 log units) from the limit.
By their numbers in this assay, from the lowest: compounds 2 and 3 (each within the scatter of the next); then compound 1. At a limit, above all of these: compound 4.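

For compound 4 the reading > 10000 nM in this assay is a limit of the assay and not a number. With an at least 19-fold higher number from compound 3 to compound 4 (1.28 log units; beyond the scatter) and an at least 27-fold higher number from compound 2 to compound 4 (1.43 log units; beyond the scatter) on the carbonyl carbon, the change is large, so this position does not treat every small heteroaryl alike, although the pyridin-2-yl of compound 2 and the 5-bromothiophen-2-yl of compound 3 could not be told apart. The earlier compounds showed only gains over the 3,4-dimethoxyphenyl of compound 1, whereas an at least 3.0-fold higher number from compound 1 to compound 4 (0.48 log units; beyond the scatter) runs the other way and makes the 1H-pyrrol-2-yl the one group shown that falls behind it.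

The compounds shown leave open whether the loss goes with the hydrogen-bond donor that enters with the 1H-pyrrol-2-yl, with the ring hetero atom, or with the bromine that leaves, since all of these change together in the single step from compound 3. As far as these compounds go, a 1-methylpyrrol-2-yl group, a thiophen-2-yl group without bromine or a 5-bromopyrrol-2-yl group on the same carbonyl carbon would pull these apart, and how far the reading of compound 4 actually lies beyond its limit also stays unknown.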